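The source may hold more compounds than are shown below. What is called first, only, known or untested is meant among the compounds shown, and "the series" means these compounds.

Measured so far:
compound 1 `c1csc(-c2noc(-c3ccc(C4=NCCN4)cc3)n2)c1`, which in an assay for inhibition of Amine oxidase [flavin-containing] B (Homo sapiens), read by fluorescence and spectrophotometry, using microsomes, with stated times of 30 min and 20 min (a lower number here means a stronger inhibitor, a higher number a weaker inhibitor), gives 890 nM;
compound 2 `Cc1ccc(Cc2noc(-c3ccc(C4=NCCN4)cc3)n2)cc1`, which in this assay gives 3640 nM.

Compound 2 stands highest of the two numbers; its nearest neighbour is compound 1, which lies lower. Compound 3 `Clc1ccc(-c2noc(-c3ccc(C4=NCCN4)cc3)n2)cc1Cl` differs from compound 2 by 3,4-dichlorophenyl in place of 4-methylbenzyl on an aromatic carbon. Among the compounds with values here, the one measured step, a 4.1-fold higher number from compound 1 to compound 2 (0.61 log units; beyond the scatter), also exchanged the group at this position, and the number rose as an aryl group gave way to a benzyl group. Compound 3, like compound 1, again bears an aryl group rather than a benzyl group, so a downward step is expected in this assay, a 4.6-fold lower number from compound 2 to compound 3 (0.66 log units; beyond the scatter). Compound 3 is estimated at 800 nM, with a range from 250 nM to 2500 nM.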

Compound 3, half-maximal inhibitory concentration: 12 nM
Compound 3: middle estimate off by 67-fold (1.82 log units), on the high side; measured number below the stated range.
By their numbers in this assay, from the lowest: compound 3; then compound 1; then compound 2.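

At this position in this assay, the group decides far more than the first pair suggested, with 3,4-dichlorophenyl in place of 4-methylbenzyl giving a 300-fold lower number from compound 2 to compound 3 (2.48 log units; beyond the scatter). Having an aromatic ring directly on the carbon does not settle the matter either: 3,4-dichlorophenyl in place of thiophen-2-yl still gives a 74-fold lower number from compound 1 to compound 3 (1.87 log units; beyond the scatter). Nothing available explains the size of these steps. The compounds shown leave open whether the gain rests on both chlorine atoms or on one, and whether a plain phenyl, a 4-chlorophenyl or a pyridine ring would keep it.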